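The compounds below may be only part of what the source reports. "The series", "measured", "known", "first", "only" and "open" are said of these compounds alone.

Measured so far in a toxicity assay on MT4 cells (Homo sapiens) for cytotoxicity, read by MTT assay, with a stated time of 7 days; on this read-out lower numbers stand for higher toxicity in this test and higher numbers for lower toxicity in this test:

- compound 1 `Cc1cc(C)cc(S(=O)(=O)c2c(C(=O)NC3CC4(C3)CN(S(C)(=O)=O)C4)[nH]c3ccc(Cl)cc23)c1` gives > 233000 nM as a limit
- compound 2 `Cc1cc(C)cc(S(=O)(=O)c2c(C(=O)NC3CC4(CCN(S(C)(=O)=O)C4)C3)[nH]c3ccc(Cl)cc23)c1` gives 205000 nM as its value
- compound 3 `Cc1cc(C)cc(S(=O)(=O)c2c(C(=O)NC3CC4(CCN(CC(N)=O)C4)C3)[nH]c3ccc(Cl)cc23)c1` gives 3700 nM as its value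

Compound 1 stands at the limit of > 233000 nM in this assay, at which 1 of the 3 values shown sits, and so carries a limit and not a number. Compound 4 `Cc1cc(C)cc(S(=O)(=O)c2c(C(=O)NC3CC4(C3)CN(C(=O)OC(C)(C)C)C4)[nH]c3ccc(Cl)cc23)c1` differs from it by one change, (tert-butoxycarbonyl in place of methylsulfonyl on an amine nitrogen in a ring), which is tert-butoxycarbonyl in place of methylsulfonyl on an amine nitrogen in a ring. Within the data shown here, no measured step makes exactly this change. The closest is a 55-fold lower number from compound 2 to compound 3 (1.74 log units; beyond the scatter), where methylsulfonyl also leaves an amine nitrogen in a ring, though carbamoylmethyl enters. The step of an at least 62-fold lower number from compound 1 to compound 3 (1.79 log units; beyond the scatter) is of similar size and also changes the ring, while the ring change alone gives an at least 1.1-fold lower number from compound 1 to compound 2 (0.05 log units; that floor lies within the scatter) and stays within the scatter. Among the measured compounds shown here, the single exchange of this kind points downward, but the entering group here is a different one. A smaller downward step is therefore expected, namely an at least 5.8-fold lower number from compound 1 to compound 4 (0.76 log units; beyond the scatter), and a second limit remains possible. For compound 4 the estimate is 40000 nM, with an expected range of 6000 nM to 200000 nM.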

Compound 4, half-maximal cytotoxic concentration: > 224000 nM
Compound 4 was reported as a limit; the forecaster's own chance of this, stated with the estimate: 20%; middle value at least 5.6-fold (0.74 log units) away from the limit.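

In this assay, compound 1 gives > 233000 nM, which is a limit. Among these compounds, compound 4 gives > 224000 nM, also a limit, so no step between compound 1 and compound 4 can be read. The compounds shown leave open how far tert-butoxycarbonyl in place of methylsulfonyl shifts the value, and in which direction.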